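The source may report more compounds than this note shows. Statements on the series, on what has been measured and on what is new or still open speak of the compounds shown alone.

Measured compounds in a functional assay on MCF7 cells (Homo sapiens) for cytotoxicity, read by sulforhodamine B assay, with a stated time of 48 h; a higher number here means that more compound is tolerated, a lower number that less compound is tolerated:
Compound 1 `COc1ccc2[nH]cc(C(=O)/C(C#N)=C/C=C(\Cl)c3ccc(OC)c(OC)c3)c2c1` gives > 100000 nM, a limit of the assay.
Compound 2 `COc1ccc2[nH]cc(C(=O)/C(C#N)=C/C=C(\Cl)c3ccc(Br)cc3)c2c1` gives > 100000 nM, a limit of the assay.
Compound 3 `COc1ccc(/C(Cl)=C/C=C(\C#N)C(=O)c2c[nH]c3ccc(Br)cc23)cc1OC` gives > 100000 nM, a limit of the assay.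

Compound 1 stands at a limit only, as do the two others shown; all three sit at the limit of > 100000 nM in this assay, at which 3 of the 3 values shown sit. The step to compound 4 `COc1ccc2[nH]cc(C(=O)/C(C#N)=C/C=C(\Cl)c3cc(OC)c(OC)c(OC)c3)c2c1` is methoxy in place of hydrogen on an aromatic carbon. The measured steps that bear on it are a step that the two limits leave unreadable from compound 1 to compound 2 and a step that the two limits leave unreadable from compound 1 to compound 3, both unreadable between limits, so neither gives a direction or a size for a change on this aryl ring. No step beyond the scatter is expected in this assay, and the result for compound 4 is expected to remain at a limit. The estimate for compound 4 is 150000 nM, within 50000 nM to 500000 nM, and the expected step that the limit leaves unreadable from compound 1 to compound 4 is none beyond the scatter.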

Compound 4, concentration lethal to 50% of the cells: > 100000 nM
Compound 4 was reported as a limit; the forecaster's own chance of this, stated with the estimate: 85%; the middle value does not contradict the limit.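

No step can be read from compound 1 to compound 4, since both stand only at a limit: the limit of > 100000 nM in this assay, at which 4 of the 4 values shown sit.
The compounds shown leave open whether any change to the shared core gives a value that is not a limit.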